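Isobutyl to benzyl: what happens to the half-life?

The source may hold more compounds than are shown below. What is called first, only, known or untested is meant among the compounds shown, and "the series" means these compounds.

Compound 1 `CC(C)CCn1nc(C2=CCCC2)c(O)c(C2=NS(=O)(=O)c3cc(NS(C)(=O)=O)ccc3N2)c1=O` gives 0.933 h
Compound 2 `CC(C)Cn1nc(-c2cccs2)c(O)c(C2=NS(=O)(=O)c3cc(NS(C)(=O)=O)ccc3N2)c1=O` gives > 1 h

In an in vitro ADME assay on microsomes from liver (Homo sapiens) for metabolic stability, tested at 5 uM (a higher number here means that the compound lasts longer, a lower number that the compound disappears faster), compound 2 stands at > 1 h as a limit of the assay, not a number. Compound 3 `CS(=O)(=O)Nc1ccc2c(c1)S(=O)(=O)N=C(c1c(O)c(-c3cccs3)nn(Cc3ccccc3)c1=O)N2` differs from compound 2 by phenyl in place of isopropyl on a saturated chain carbon bound to an aromatic nitrogen in one place: phenyl in place of isopropyl on a saturated chain carbon bound to an aromatic nitrogen, which also reads isobutyl to benzyl. Among the measured compounds shown here, no measured pair shows this change. For the measured compounds named here, compound 1 gives 0.933 h as the only exact number, so a small fall or none beyond the scatter is expected. The estimated step in this assay is an at least 1.2-fold lower number from compound 2 to compound 3 (0.09 log units; that floor lies within the scatter) (a small fall). For compound 3 the half-life is expected to be 0.8 h (range 0.4 h to 1.5 h).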

Compound 3, half-life: > 1 h
Compound 3: no number, only a limit; the forecaster's own chance of this, stated with the estimate: 40%; at least 1.2-fold (0.09 log units) between middle value and limit.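

In this assay, compound 2 and compound 3 each give only a limit, not a number, so no step can be read between them: the limit of > 1 h in this assay, at which 2 of the 3 values shown sit.

The compounds shown leave open how long each compound actually lasts, and whether benzyl in place of isobutyl changes the half-life at all.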